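Cyclopentyl in Place of Ethyl: What to Expect for Compound 3

The compounds below may be only part of what the source reports. "The series", "measured", "known", "first", "only" and "open" are said of these compounds alone.

Among the measured compounds shown here, compound 2 `CCCN(Cc1ccc(OCCN2C(=O)CCC2=O)c(C)c1)[C@@H](CC(=O)O)c1ccc(Cl)cc1` gives 9.3 nm/s in an ADME assay on Caco-2 cells (Homo sapiens) for permeability, read by LC-MS, with a stated time of 2 h (a higher number here means that the compound crosses the layer faster, a lower number that the compound crosses the layer more slowly), one of only two numbers so far; compound 1 `CCCN(Cc1ccc(OCCN2C(=O)CCC2=O)c(C)c1)C(CC(=O)O)c1ccc(Cl)cc1` gives 10.2 nm/s, and the step of a 1.1-fold lower number from compound 1 to compound 2 (0.04 log units; within the scatter) lies within the scatter, the two compounds differing solely in the fact that one of compounds 1 and 2 is drawn with a defined configuration and the other without, at the place where they differ. Compound 3 `Cc1cc(CN(CC2CCCC2)[C@@H](CC(=O)O)c2ccc(Cl)cc2)ccc1OCCN1C(=O)CCC1=O` has not yet been measured in this assay. It differs from compound 2 by cyclopentyl in place of ethyl on a saturated chain carbon bound to an amine nitrogen. For the measured compounds named here, no measured step covers a change of this kind, so the expectation rests on compound 2 alone. Compound 3 is estimated to give 14 nm/s, between 6 nm/s and 35 nm/s, an expected step of a 1.5-fold higher number from compound 2 to compound 3 (0.18 log units; within the scatter) that may not rise beyond the scatter.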

Compound 3, apparent permeability: 18.1 nm/s
The estimate for compound 3 lay 1.3-fold (0.11 log units) below the measured number; low and high end bracket the measured number.
By their numbers in this assay, from the lowest: compounds 2, 1 and 3 (each within the scatter of the next).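

Among the compounds shown here, the step of a 1.9-fold higher number from compound 2 to compound 3 (0.29 log units; within the scatter) in this assay is the first reading at this place, on a saturated chain carbon bound to an amine nitrogen, since compounds 1 and 2 differ only in how a stereocentre is drawn. It shows that cyclopentyl can stand in place of ethyl here without a step beyond the scatter. Nothing available gives a reason for this step. Going by these compounds, whether a longer chain, a cyclohexyl ring or a hydroxyl group at this place would give a step beyond the scatter stays open.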